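Swapping One Oxadiazole Isomer for Another

The source may report more compounds than this note shows. Statements on the series, on what has been measured and on what is new or still open speak of the compounds shown alone.

Measured compounds:
- compound 1, `CCCCN(CC)c1nc(C)nc2c1c(C)nn2-c1c(C)cc(C)cc1C`: 9 nM
- compound 2, `CCCNCc1nnc(Nc2nc(C)nc3c2c(C)nn3-c2ccc(OC)cc2C)o1`: 996 nM

In a functional assay on CHO cells for antagonist activity at corticotropin-releasing factor receptor 1 (Homo sapiens), read by cAMP accumulation (a lower number here means a stronger inhibitor, a higher number a weaker inhibitor), compound 1 gives 9 nM. In this assay compound 2 gives 996 nM, which is the higher of the two numbers, and the gap to compound 1 lies well beyond the usual scatter. Compound 1 and compound 2 differ in several places at once, so nothing further can be read from that pair.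

Compound 3, `CCCNCc1noc(Nc2nc(C)nc3c2c(C)nn3-c2ccc(OC)cc2C)n1`, has not yet been measured. Compared with compound 2 the change is 3-((propylamino)methyl)-1,2,4-oxadiazol-5-yl in place of 5-((propylamino)methyl)-1,3,4-oxadiazol-2-yl on a nitrogen on an aromatic ring. The two rings contain the same atoms, joined differently, and the propylaminomethyl chain stays in place. Within the data shown here, with no measured step of this kind available, the expectation is a change that stays within the scatter, in no clear direction. Compound 3 is therefore expected to give about 850 nM in this assay, with a likely range from 250 nM to 3000 nM. This estimate corresponds to a step of a 1.2-fold lower number from compound 2 to compound 3 (0.07 log units; within the scatter), which is expected to be small.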

Compound 3, inhibition constant: 84 nM
The estimate for compound 3 lay 10-fold (1.01 log units) above the measured number; the whole stated range lies above it.
By their numbers in this assay, from the lowest: compound 1; then compound 3; then compound 2.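

In this assay, swapping one oxadiazole isomer for the other gives a 12-fold lower number from compound 2 to compound 3 (1.07 log units; beyond the scatter) and so shows that at this place on the shared core, the way the ring atoms are joined can matter a great deal. The group that leaves and the group that enters, 5-((propylamino)methyl)-1,3,4-oxadiazol-2-yl and 3-((propylamino)methyl)-1,2,4-oxadiazol-5-yl, have the same atoms and the same counts of hydrogen-bond donors and acceptors, so those counts alone do not separate the two compounds. Among these compounds, this is also the first comparison here that isolates a single change, but no supporting measurement is available to explain the difference.

This single pair cannot show whether the preference for the 1,2,4-oxadiazole would hold with a different chain on the ring, such as a butylaminomethyl or a dimethylaminomethyl chain. It also leaves open how other five-membered rings in the same place, such as a 1,2,4-triazole or a 1,3,4-thiadiazole, would compare with these two isomers.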